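Naphthyl sulfonamide on a shared quinazoline-free core: what to expect

The compounds below may be only part of what the source reports. "The series", "measured", "known", "first", "only" and "open" are said of these compounds alone.

Measured so far:
- compound 1, `COc1cc2nc(N3CCN(S(=O)(=O)c4cc(Cl)ccc4Cl)CC3)nc(N)c2cc1OC`: 60000 nM
- compound 2, `COc1cc2nc(N3CCN(S(=O)(=O)c4cc(C(=O)O)c(Cl)cc4Cl)CC3)nc(N)c2cc1OC`: 52000 nM

Of the compounds shown here, two have been tested in a functional assay on PC-3 cells (Homo sapiens) for inhibition; a higher number here means a weaker inhibitor, a lower number a stronger inhibitor. Compound 1 `COc1cc2nc(N3CCN(S(=O)(=O)c4cc(Cl)ccc4Cl)CC3)nc(N)c2cc1OC` gives 60000 nM in this assay, and compound 2 `COc1cc2nc(N3CCN(S(=O)(=O)c4cc(C(=O)O)c(Cl)cc4Cl)CC3)nc(N)c2cc1OC` gives 52000 nM. Both numbers are high, so both compounds are weak inhibitors. The one step between them, a 1.2-fold lower number from compound 1 to compound 2 (0.06 log units; within the scatter), falls within the scatter, so compound 2 and compound 1 stand at the same level on the numbers shown.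

Compound 3 `COc1cc2nc(N3CCN(S(=O)(=O)c4ccc5ccccc5c4)CC3)nc(N)c2cc1OC` is not yet measured. It differs from compound 2 in one place: naphthalen-2-yl in place of 5-carboxy-2,4-dichlorophenyl on a sulfonyl sulfur. Among the compounds with values here, the only measured step, a 1.2-fold lower number from compound 1 to compound 2 (0.06 log units; within the scatter), concerns a different change on the same sulfonyl sulfur and gave no shift beyond the scatter. It therefore offers no ground to expect a large movement in this assay for compound 3 in either direction. The expected step of a 1.2-fold lower number from compound 2 to compound 3 (0.06 log units; within the scatter) is small and within the scatter. Compound 3 is estimated at 45000 nM in this assay, with a range from 12000 nM to 150000 nM.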

Compound 3, half-maximal inhibitory concentration: 15000 nM
For compound 3 the middle estimate is 3.0-fold (0.48 log units) above the measured one; measured number inside the range.
By their numbers in this assay, from the lowest: compound 3; then compounds 2 and 1 (each within the scatter of the next).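

The group on the sulfonyl sulfur can move the number in this assay after all: the earlier change at this place stayed within the scatter, but naphthalen-2-yl brings a 3.5-fold lower number from compound 2 to compound 3 (0.54 log units; beyond the scatter) and also a 4.0-fold lower number from compound 1 to compound 3 (0.60 log units; beyond the scatter) in the same direction. Replacing either chlorinated phenyl group with naphthalen-2-yl therefore goes with a stronger inhibitor, and this change adds a second six-membered aromatic ring of carbon only and removes the chlorine atoms. Both steps are modest, though, and compound 3 at 15000 nM is still a weak inhibitor, while nothing measured alongside these numbers explains the gain.

The second ring and the loss of chlorine arrive together, so the compounds shown leave open which of them goes with the lower number, a question that a plain phenyl ring carrying no chlorine on the sulfonyl sulfur could help to separate. Also open, from the compounds shown here alone, is how far this position can be pushed, for example whether an amine or a methoxy group on the naphthalen-2-yl ring would lower the number further or raise it again.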